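Notes on compound 1 and the step to compound 3

This account rests on a few compounds, and the source may have more. Where it says the series, first, only, none or still open, it means among the compounds named here.

Compound 1 `CN(C(=S)SCc1ccc(C(=O)Nc2ccccc2N)cc1)c1cccnc1` holds the higher of the two measured numbers. In a functional assay on MGC-803 cells (Homo sapiens) for antiproliferative activity, read by CCK-8 assay, with a stated time of 72 h, tested at 2 uM (on this read-out lower numbers stand for a weaker effect and higher numbers for a stronger effect at the one concentration tested), compound 1 gives 46.1%, and compound 2 `Nc1ccccc1NC(=O)c1ccc(CSC(=S)N2CCN(c3ncccn3)CC2)cc1` gives 28.4%; the gap between these two values lies beyond the usual scatter, so compound 1 stands as the stronger of the pair. Going by the values given here, no step between measured compounds that differ in one place exists in this set, so the move to compound 3 `CN(Cc1ccncc1)C(=S)SCc1ccc(C(=O)Nc2ccccc2N)cc1` rests on structure alone. Compound 3 differs from compound 1 by (pyridin-4-yl)methyl in place of pyridin-3-yl on an amide-type nitrogen. Nothing measured shows how such a replacement acts in this series. A step of modest size is expected, most likely a small fall or none beyond the scatter, and the expected step in this assay is a number 6.1 percentage points lower from compound 1 to compound 3 (within the scatter). Compound 3 is estimated to give 40% in this assay, with a range from 22% to 58%.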

Compound 3, a percentage reported as inhibition, at one concentration (the size of the read-out at that concentration, not a potency): 38.1%
Compound 3: the middle estimate sits 1.9 percentage points above what was measured; the range from low to high includes it.
By their numbers in this assay, from the lowest: compounds 2, 3 and 1 (each within the scatter of the next, the first and the last beyond it).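

In this assay, the first step read at this position, on the amide-type nitrogen, is a number 8 percentage points lower from compound 1 to compound 3 (within the scatter), so compound 1 and compound 3 cannot be told apart on this read-out. The position thus accepts (pyridin-4-yl)methyl in place of pyridin-3-yl without a step beyond the scatter, although this single replacement alters both the ring attachment and the link to the nitrogen and cannot separate the two. Nothing available explains the outcome of this replacement.

As far as these compounds go, how pyridin-4-yl or (pyridin-3-yl)methyl would read on its own remains open, and either group would help to separate the two alterations. Also open, from the compounds shown here alone, are a benzyl group or a morpholine at this nitrogen, and an ethyl group or a longer chain in place of its methyl.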